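The source may report more compounds than this note shows. Statements on the series, on what has been measured and on what is new or still open speak of the compounds shown alone.

Measured so far:
Compound 1, `CCn1c(-c2cnc(C)nc2)nc2c(N[C@H]3CCN(C(=O)N4CC(OC)C4)C3)ncnc21`, gives 4 h in an ADME assay (Rattus norvegicus, strain Wistar Han) for metabolic stability; on this read-out lower numbers stand for a shorter-lived compound and higher numbers for a longer-lived compound.
Compound 2, `CCn1c(-c2cnc(C)nc2)nc2c(N[C@H]3CCN(C(=O)c4cocn4)C3)ncnc21`, gives 0.7 h.
Compound 3, `CCn1c(-c2ccc(C(F)(F)F)nc2)nc2c(O[C@H]3CCN(C(=O)N4CC(OC)C4)C3)ncnc21`, gives 2 h.

Compound 1 and compound 2 share one core and differ in a single place, (1,3-oxazol-4-yl in place of 3-methoxyazetidin-1-yl on a carbonyl carbon), and that change brought a 5.7-fold lower number from compound 1 to compound 2 (0.76 log units; beyond the scatter). Compound 4, `CCn1c(-c2ccc(C(F)(F)F)nc2)nc2c(O[C@H]3CCN(C(=O)c4cocn4)C3)ncnc21`, is not yet measured; it relates to compound 3 in the same way, (1,3-oxazol-4-yl in place of 3-methoxyazetidin-1-yl on a carbonyl carbon), with the same surroundings at that place. The difference between the two cores, that of compound 1 and that of compound 3, is not broken down here; the values of compound 1 and compound 3 lie within the scatter of each other. The step expected for compound 4 is a 5.7-fold lower number from compound 3 to compound 4 (0.76 log units; beyond the scatter), resting on the single earlier case in which compound 1 showed a 5.7-fold lower number from compound 1 to compound 2 (0.76 log units; beyond the scatter). Compound 4 is thus estimated at 0.35 h in this assay, between 0.15 h and 0.9 h.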

Compound 4, half-life: 6 h
Beside the measured number, compound 4's estimate is 17-fold (1.23 log units) below it; measured number above the stated range.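

In this assay, placing 1,3-oxazol-4-yl on the carbonyl carbon instead of 3-methoxyazetidin-1-yl gave a 3.0-fold higher number from compound 3 to compound 4 (0.48 log units; beyond the scatter). The change therefore did not carry over from one core to the other, and its direction reversed: the same change on two cores in this assay, a 5.7-fold lower number (0.76 log units; beyond the scatter) from compound 1 to compound 2 and a 3.0-fold higher number (0.48 log units; beyond the scatter) from compound 3 to compound 4, 17-fold (1.23 log units) apart, beyond the scatter of two such steps This shows that, in these two pairs, the outcome of the swap depends on the core, but it does not show which part of the core difference matters, and two pairs set no rule for the series.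

On these data alone, it remains open how each part of the core difference would act on its own. Also open, as far as these compounds go, is how another group on the carbonyl carbon, such as dimethylamino or phenyl, would behave on each core.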